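This account rests on a few compounds, and the source may have more. Where it says the series, first, only, none or still open, it means among the compounds named here.

In a functional assay on KARPAS-422 cells (Homo sapiens) for antiproliferative activity, read by resazurin assay, with a stated time of 72 h (on this read-out lower numbers stand for stronger inhibition and higher numbers for weaker inhibition), compound 1 `COC(c1cc(Cl)c2c(c1Cl)C(=O)N(Cc1c(C)cc(C)[nH]c1=O)CC2)C1CCOCC1` gives 1150 nM; 19 nM (2 entries), and compound 2 `Cc1cc(C)c(CN2CCc3c(Cl)cc(C(CO)c4ccon4)c(Cl)c3C2=O)c(=O)[nH]1` gives 2490 nM; 122 nM (2 entries), so each has two entries lying far apart. Compound 3 `Cc1cc(C)c(CN2CCc3c(Cl)cc([C@H](CO)[C@@H]4CCCO4)c(Cl)c3C2=O)c(=O)[nH]1` has a single number, 57 nM, which falls within the span of those lower entries. Compound 4 `Cc1cc(C)c(CN2CCc3c(Cl)cc([C@@H](CO)[C@@H]4CCCO4)c(Cl)c3C2=O)c(=O)[nH]1` has the same atoms and bonds: the two compounds have the same atoms and bonds and differ only in configuration as drawn: 1 of 2 stereo elements differ; a stereocentre at a saturated chain carbon is drawn R in compound 3 and S in compound 4, with a stereocentre at a saturated chain carbon drawn R in compound 3 and S in compound 4. For the measured compounds named here, no measured pair shows this change alone. Taking the wide gaps in the several entries of compound 1 in this assay, 1150 nM; 19 nM (2 entries) and the several entries of compound 2 in this assay, 2490 nM; 122 nM (2 entries) as a rough guide, a weakening beyond the usual scatter is expected in this assay. The expected change is a 16-fold higher number from compound 3 to compound 4 (1.20 log units; beyond the scatter). Compound 4 is estimated at 900 nM, within an expected range of 60 nM to 4000 nM.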

Compound 4, half-maximal inhibitory concentration: 1220 nM
Estimate against measurement, compound 4: 1.4-fold (0.13 log units) below; the range from low to high includes it.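

In this assay, changing one stereocentre at a saturated chain carbon from R to S, with no atom added or removed, gives a 21-fold higher number from compound 3 to compound 4 (1.33 log units; beyond the scatter). For the compounds shown here, compounds 1 and 2 offered no such single-place comparison, so this is the first clean measure of how much the drawn configuration at this carbon matters. The gap can be assigned to that configuration alone: the fact that compounds 3 and 4 differ only in the configuration as drawn.

From the compounds shown here alone, the effect of the second stereocentre, drawn the same in both compounds, remains open. So does whether the same preference would hold with an amine in place of the hydroxyl group on the chain.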